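Removing one methoxy group from a cinnamanilide pair

The compounds below may be only part of what the source reports. "The series", "measured", "known", "first", "only" and "open" are said of these compounds alone.

Measured so far in a functional assay on COLO 205 cells (Homo sapiens) for cytotoxicity, read by MTT assay, with a stated time of 72 h; on this read-out lower numbers stand for stronger inhibition and higher numbers for weaker inhibition:
compound 1 `COc1cccc(/C=C/C(=O)Nc2cc(OC)c(OC)c(OC)c2)c1` gives 4200 nM
compound 2 `COc1ccc(C(=O)c2cc(OC)c(OC)c(OC)c2)cc1NC(=O)/C=C/c1ccc(OC)c(OC)c1` gives 8200 nM

Compound 2 stands at the higher of the two numbers, but its nearest neighbour, compound 1, lies within the scatter of it, so the two cannot be ranked against each other on this evidence. The two compounds differ in several places at once, and no single-point comparison between measured compounds is available.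

Compound 3 `COc1cccc(/C=C/C(=O)Nc2cc(C(=O)c3cc(OC)c(OC)c(OC)c3)ccc2OC)c1` is the unmeasured compound. It differs from compound 2 in one place: hydrogen in place of methoxy on an aromatic carbon. The change sits on an aromatic carbon of a six-membered aromatic ring of carbon only, ortho to a methoxy group and para to a large group, so that the 3,4-dimethoxyphenyl end becomes a 3-methoxyphenyl end. The same 3-methoxyphenyl end is present in compound 1, whose number lies within the scatter of compound 2.

On this basis the step from compound 2 to compound 3 is expected to be small, with no direction beyond the scatter; the estimated change is a 1.2-fold lower number from compound 2 to compound 3 (0.07 log units; within the scatter). Compound 3 is accordingly expected to give about 7000 nM, within a range from 2500 nM to 20000 nM.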

Compound 3, half-maximal inhibitory concentration: 5100 nM
Beside the measured number, compound 3's estimate is 1.4-fold (0.14 log units) above it; measured number inside the range.
By their numbers in this assay, from the lowest: compounds 1, 3 and 2 (each within the scatter of the next).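

Going by these compounds alone, this pair gives the first comparison of compounds that differ in one place: with hydrogen in place of methoxy on an aromatic carbon, ortho to a methoxy group and para to a large group, this assay shows a 1.6-fold lower number from compound 2 to compound 3 (0.21 log units; within the scatter). The 3,4-dimethoxyphenyl end and the 3-methoxyphenyl end therefore cannot be told apart on this read-out, and within this pair the methoxy group at this position makes no difference that stands clear of the scatter. No other measurement bears on this result, so the pair gives no account of why the two compounds read alike.

The compounds shown leave open whether a different group on this same aromatic carbon, such as a hydroxyl group, an amine or a carboxylic acid, would give a step beyond the scatter. They also leave open what the methoxy group that remains on the 3-methoxyphenyl end contributes, since no compound shown has hydrogen or any other group in its place.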